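A few compounds are considered here, and "the series" means these few. Any claim that something is new, unique, unknown or untested is made for them only; others in the source may bear on it.

The compounds measured so far in a functional assay on the whole organism for antagonist activity, with Mus musculus as the target; on this read-out lower numbers stand for an effect already at smaller amounts and higher numbers for an effect only at larger amounts of compound:

compound 1, `CC(NC(=O)CN)C(=O)N(C)c1ccc(Cl)cc1C(=O)c1ccccc1Cl`, giving 0.47 mg/kg
compound 2, `CCCC(=O)NCC(=O)N(C)c1ccc(Cl)cc1C(=O)c1ccccc1Cl`, giving 0.98 mg/kg
compound 3, `CN(C(=O)CNC(=O)c1ccccc1)c1ccc(Cl)cc1C(=O)c1ccccc1Cl`, giving 2.9 mg/kg

Compound 2 holds the second highest number of the three. Its nearest neighbour is compound 1, with a 2.1-fold higher number from compound 1 to compound 2 (0.32 log units; beyond the scatter), and the step to the other side is a 3.0-fold higher number from compound 2 to compound 3 (0.47 log units; beyond the scatter). Both steps are modest and both lie beyond the scatter, so the acyl group on this amide does move the read-out in this assay.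

Compound 4, `CCCCCCCCCCCCCCCC(=O)NCC(=O)N(C)c1ccc(Cl)cc1C(=O)c1ccccc1Cl`, has not yet been measured. It differs from compound 2 in one place: dodecyl in place of hydrogen on a saturated chain carbon, three bonds along the chain from a carbonyl carbon. The measured steps offer no chain extension of this kind; the nearest guide is the exchange of propyl for phenyl on the same carbonyl carbon, which gave a 3.0-fold higher number from compound 2 to compound 3 (0.47 log units; beyond the scatter), and the exchange at the other acyl position, which gave a 2.1-fold higher number from compound 1 to compound 2 (0.32 log units; beyond the scatter). Both changes at this position raised the number, so compound 4 is expected to sit at a somewhat higher number than compound 2, though the size is uncertain. Compound 4 is estimated to give 2.5 mg/kg, between 0.8 mg/kg and 8 mg/kg. That estimate corresponds to a 2.6-fold higher number from compound 2 to compound 4 (0.41 log units; beyond the scatter).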

Compound 4, dose for half-maximal effect: > 100 mg/kg
Compound 4: only a limit was reported; the forecaster's own chance of this, stated with the estimate: 15%; middle value at least 40-fold (1.60 log units) from the limit.
By their numbers in this assay, from the lowest: compound 1; then compound 2; then compound 3. At a limit, above all of these: compound 4.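

In this assay, going by these compounds alone, this position proves far more sensitive to the size of the acyl chain than the earlier compounds suggested: dodecyl in place of hydrogen on a saturated chain carbon, three bonds along the chain from a carbonyl carbon, gives an at least 100-fold higher number from compound 2 to compound 4 (2.00 log units; beyond the scatter), the only large step. The earlier exchange on the same carbonyl carbon stayed modest, with a 3.0-fold higher number from compound 2 to compound 3 (0.47 log units; beyond the scatter), so nothing among the three earlier compounds foretold a change of this size from extending the chain alone. Compound 4 has only a limit and not an exact number, so the true size of the step remains unknown beyond what is printed: the limit of > 100 mg/kg in this assay, at which 1 of the 4 values shown sits.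

The compounds shown leave open at what length the number begins to climb, since nothing lies between the propyl of compound 2 and the far longer chain of compound 4; a hexyl or an octyl chain would fall in that gap. They also leave open whether a long chain carrying an amine or a carboxylic acid would behave as the plain chain of compound 4 does.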